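The compounds below may be only part of what the source reports. "The series", "measured", "known", "first", "only" and "open" are said of these compounds alone.

Compound 1 `O=P(O)(O)OP(=O)(O)OP(=O)(O)OC[C@H]1O[C@@H](c2nc3c(F)cc(Cl)cc3s2)[C@H](O)[C@@H]1O` is one of three nucleotide analogues measured in a functional assay for agonist activity at P2Y purinoceptor 2 (Homo sapiens), read by FLIPR; on this read-out lower numbers stand for an effect already at smaller amounts and higher numbers for an effect only at larger amounts of compound. In this assay compound 1 gives 7 nM, the second highest of the three numbers. Among the compounds with values here, compound 3 `O=c1c2cc(F)ccc2ccn1[C@@H]1O[C@H](COP(=O)(O)OP(=O)(O)OP(=O)(O)O)[C@@H](O)[C@H]1O` is its nearest neighbour: in this assay compound 3 gives 5 nM, a number that sits within the usual scatter of the one for compound 1, so no order between the two can be claimed. Compound 2 `COc1cccc2sc([C@@H]3O[C@H](COP(=O)(O)OP(=O)(O)OP(=O)(O)O)[C@@H](O)[C@H]3O)nc12` is the furthest away: in this assay compound 2 gives 700 nM, a gap from compound 1 that lies well beyond the scatter.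

The next compound, compound 4 `O=P(O)(O)OP(=O)(O)OP(=O)(O)OC[C@H]1O[C@@H](c2nc3ccc(Cl)cc3s2)[C@H](O)[C@@H]1O`, has not been measured in this assay. It differs from compound 1 in one place (hydrogen in place of fluoro on an aromatic carbon), the fluoro leaving the six-membered aromatic ring of carbon only while the chloro group stays. Within the data shown here, no step between measured compounds tells what removing this fluoro does here. The expected step from compound 1 to compound 4 in this assay is a 1.7-fold higher number from compound 1 to compound 4 (0.23 log units; within the scatter), small and not clearly beyond the scatter, with a slight lean toward a higher number. For compound 4 the estimated value in this assay is therefore 12 nM, expected to fall between 4 nM and 40 nM.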

Compound 4, half-maximal effective concentration: 8 nM
For compound 4 the middle estimate is 1.5-fold (0.18 log units) above the measured one; low and high end bracket the measured number.
By their numbers in this assay, from the lowest: compounds 3, 1 and 4 (each within the scatter of the next); then compound 2.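

In this assay, putting hydrogen in place of fluoro on this aromatic carbon, ortho to a fused ring, gives a 1.1-fold higher number from compound 1 to compound 4 (0.06 log units; within the scatter) with the chloro group kept in both compounds. With the chloro group present, the fluoro at this position is therefore not needed for a number in the low range that compound 1 already showed, and hydrogen and fluoro cannot be told apart here. Nothing available explains why this exchange leaves the number in place.

Still open, from the compounds shown here alone, is how a larger group on this same carbon, such as an amine or a carboxylic acid, would compare with hydrogen and fluoro. Equally open, going by these compounds, is what hydrogen or a nitrile in place of the chloro group would do on the core of compound 4.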